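Swapping a Methoxy for Isopropyl on a Receptor Binder

A few compounds are considered here, and "the series" means these few. Any claim that something is new, unique, unknown or untested is made for them only; others in the source may bear on it.

Compound 1 `CCN(c1nc(C)cc(C)n1)c1c(Br)cc(OC)cc1OC` — 12 nM
Compound 2 `CCN(CC)c1cc(C)nc(N(CC)c2c(Br)cc(OC)cc2OC)n1` — 48 nM

Of the compounds shown here, two have so far been measured in an assay on isolated protein for binding affinity to corticotropin-releasing factor receptor 1 (Homo sapiens); on this read-out lower numbers stand for stronger inhibition and higher numbers for weaker inhibition. Compound 1 gives 12 nM and compound 2 gives 48 nM; the step of a 4.0-fold higher number from compound 1 to compound 2 (0.60 log units; beyond the scatter) came with diethylamino in place of methyl on an aromatic carbon. Compound 1 therefore holds the lowest of the two numbers, and compound 2 is its nearest neighbour.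

Compound 3 `CCN(c1nc(C)cc(C)n1)c1c(Br)cc(C(C)C)cc1OC` has not yet been measured. It differs from compound 1 in a single place: isopropyl in place of methoxy on an aromatic carbon The site is an aromatic carbon of a six-membered aromatic ring of carbon only, meta to a bromo group, meta to a methoxy group and para to a large group. Among the measured compounds shown here, the only measured step concerns a different part of the shared core, so no measured step bears directly on this change; the data give no guide to its size or direction. Compound 3 is therefore expected to stay close to compound 1, with a step of no change at the digits printed from compound 1 to compound 3 (within the scatter) that is expected to lie within the scatter. Compound 3 is estimated at 12 nM, likely between 4 nM and 40 nM.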

Compound 3, inhibition constant: 26 nM
For compound 3 the middle estimate is 2.2-fold (0.34 log units) below the measured one; the measured number falls inside the stated range.
By their numbers in this assay, from the lowest: compound 1; then compounds 3 and 2 (each within the scatter of the next).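

In this assay, among the compounds shown here, this change gives the first measured step at the aromatic carbon para to a large group: isopropyl in place of methoxy produces a 2.2-fold higher number from compound 1 to compound 3 (0.34 log units; beyond the scatter). The step is modest but real, so this position does respond to what it carries, even though compound 3 stays in the nanomolar range at 26 nM without the methoxy group, which counts as a hydrogen-bond acceptor where isopropyl does not. Nothing in the available data accounts for the rise in the number, so the step stands here as an observation with no explanation attached.

This single swap changes both the oxygen and the branched carbon shape at once, so it cannot show which of these goes with the step, and an ethyl group, an ethoxy group or a lone chlorine atom at the same place would help to separate them. It also leaves open whether the step at this position and the step seen on replacing methyl with diethylamino would add up if both changes were made in one compound.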